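Chlorophenyl placement: working notes on compound 3

The compounds below may be only part of what the source reports. "The series", "measured", "known", "first", "only" and "open" are said of these compounds alone.

Compound 1 `NC(=O)c1cc(Br)ccc1NC(=O)/C=C/c1ccccc1`: 5000 nM
Compound 2 `NC(=O)c1cc(Br)ccc1NC(=O)/C=C/c1ccccc1Cl`: 8100 nM

For the measured compounds named here, in a functional assay on K562 cells (Homo sapiens) for inhibition, read by trypan blue exclusion, with a stated time of 48 h (on this read-out lower numbers stand for stronger inhibition and higher numbers for weaker inhibition), compound 2 stands within the scatter of compound 1, the only other measured compound. Compound 3 `NC(=O)c1cc(Br)ccc1NC(=O)/C=C/c1cccc(Cl)c1` has 3-chlorophenyl in place of 2-chlorophenyl on a double-bonded chain carbon bound to a double-bonded chain carbon. Going by the values given here, the only measured step bearing on this is a 1.6-fold higher number from compound 1 to compound 2 (0.21 log units; within the scatter), which adds the chloro group but does not test its position. No step beyond the scatter is therefore expected in this assay. The expected step is a 1.2-fold lower number from compound 2 to compound 3 (0.10 log units; within the scatter). For compound 3 the estimated value is 6500 nM, with an expected range of 2800 nM to 15000 nM.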

Compound 3, half-maximal inhibitory concentration: > 10000 nM
Compound 3: a limit, no number; the forecaster's own chance of this, stated with the estimate: 3%; middle value at least 1.5-fold (0.18 log units) from the limit.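

In this assay compound 3 reads as a limit and not a number: the limit of > 10000 nM in this assay, at which 1 of the 3 values shown sits. Moving the chloro group to give 3-chlorophenyl produces an at least 1.2-fold higher number from compound 2 to compound 3 (0.09 log units; that floor lies within the scatter), and against the unsubstituted compound the change is an at least 2.0-fold higher number from compound 1 to compound 3 (0.30 log units; that floor lies within the scatter). Compound 1 and compound 2 both read as numbers. Neither floor shows a step beyond the scatter.

On these data alone, the true size of both steps stays open. So does whether an amine or a carboxylic acid in place of the chloro group of 3-chlorophenyl would give a number in this assay.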